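Amide to sulfonamide exchange on the lactam series

The source may hold more compounds than are shown below. What is called first, only, known or untested is meant among the compounds shown, and "the series" means these compounds.

Working notes. Compound 2 `CCN1CCN(c2cccc3c2CN([C@H](CCCNC(=O)c2c(C)n[nH]c2C)c2ccc(OC)c(OC)c2)C3=O)CC1` gives 11 nM in an assay on RMS13 cells for displacement of a labelled ligand from Urotensin-2 receptor (Homo sapiens), read by scintillation proximity assay; a higher number here means a weaker inhibitor, a lower number a stronger inhibitor. Compound 1 `CCN1CCN(c2cccc3c2C(=O)N([C@H](CCCNS(=O)(=O)c2cn(C)c(C)n2)c2ccc(OC)c(OC)c2)C3=O)CC1` gives 97 nM in this assay, so compound 2 holds the lower of the two numbers, and the gap between them is beyond the usual scatter. Compounds 1 and 2 differ in more than one place, so no single step can be read from that pair.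

Compound 3 `CCN1CCN(c2cccc3c2CN([C@H](CCCNS(=O)(=O)c2c[nH]cn2)c2ccc(OC)c(OC)c2)C3=O)CC1` is not yet measured. It keeps the core of compound 2 and carries the change ((1H-imidazol-4-yl)sulfonyl in place of (3,5-dimethyl-1H-pyrazol-4-yl)carbonyl on an amine nitrogen). Going by the values given here, no measured pair isolates this exchange. A step beyond the scatter toward a higher number is expected in this assay, since compound 1, the only other sulfonamide in the set, gives 97 nM on a different core. For compound 3 the estimated value is 35 nM, with a range of 9 nM to 140 nM. The step expected from this estimate is a 3.2-fold higher number from compound 2 to compound 3 (0.50 log units; beyond the scatter).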

Compound 3, inhibition constant: 25 nM
Estimate against measurement, compound 3: 1.4-fold (0.15 log units) above; the range from low to high includes it.
By their numbers in this assay, from the lowest: compound 2; then compound 3; then compound 1.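

Going by these compounds alone, the exchange of (3,5-dimethyl-1H-pyrazol-4-yl)carbonyl for (1H-imidazol-4-yl)sulfonyl on the amine nitrogen gives a 2.3-fold higher number from compound 2 to compound 3 (0.36 log units; beyond the scatter) in this assay, the first step at this position that can be read on a single core. The position therefore accepts a sulfonyl group in place of the carbonyl at a modest cost, and compound 3 stays in the same low range of numbers as compound 2 on this core. No measurement shown here explains the size of the step.

The exchange alters the linking group and the ring together, so their shares of the step remain unresolved. A (3,5-dimethyl-1H-pyrazol-4-yl)sulfonyl or (1H-imidazol-4-yl)carbonyl group on the same amine nitrogen would separate the two.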